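Taking the ring methyl off compound 2

The source may hold more compounds than are shown below. What is called first, only, known or untested is meant among the compounds shown, and "the series" means these compounds.

Values in a functional assay on MDCK cells (Canis lupus familiaris) for inhibition; a lower number here means that less compound is tolerated, a higher number that more compound is tolerated:
Compound 1 `COc1nc(CC2(c3ccccc3)CCCO2)cc(=O)n1C`: 130000 nM
Compound 2 `COc1nc(CC2(C)CCCO2)cc(=O)n1C`: 1620000 nM
Compound 3 `Cn1c(OC2CCCCC2)nc(CC2(C)CCCO2)cc1=O`: 816000 nM

Compound 2 belongs to the upper pair of these numbers, and a 2.0-fold lower number from compound 2 to compound 3 (0.30 log units; within the scatter) leaves it level with its partner. Compound 4 `COc1nc(CC2CCCO2)cc(=O)n1C` differs from compound 2 by hydrogen in place of methyl on a saturated ring carbon. That step, at the other site, says little here. The measured change at this same carbon is a 12-fold higher number from compound 1 to compound 2 (1.10 log units; beyond the scatter), which was large but exchanged phenyl, not a lone methyl. Removing only methyl is a smaller change, so little movement in this assay is anticipated. The expected step is a 1.1-fold higher number from compound 2 to compound 4 (0.05 log units; within the scatter), which would stay within the scatter. For compound 4 the estimated value is 1800000 nM, with an expected range of 800000 nM to 4000000 nM.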

Compound 4, half-maximal cytotoxic concentration: 1220000 nM
Compound 4: the middle estimate sits 1.5-fold (0.17 log units) above what was measured, within the range that was stated.
By their numbers in this assay, from the lowest: compound 1; then compounds 3, 4 and 2 (each within the scatter of the next).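

Replacing methyl with hydrogen on this saturated ring carbon, next to the ring oxygen, gives a 1.3-fold lower number from compound 2 to compound 4 (0.12 log units; within the scatter) in this assay and so leaves the number within the scatter. Phenyl at the same carbon stands apart from hydrogen as well as from methyl, with a 9.4-fold higher number from compound 1 to compound 4 (0.97 log units; beyond the scatter) in this assay, so among these three groups only phenyl separates from the others. No supporting measurement bears on why these steps differ in size.

On these data alone, how an ethyl, a hydroxymethyl or an amine group at this carbon would compare remains open.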